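Fluoro Addition Across Two Related Antagonist Cores

The source may report more compounds than this note shows. Statements on the series, on what has been measured and on what is new or still open speak of the compounds shown alone.

Compound 1 `CC(C(=O)NCc1ccc(C(F)(F)F)cc1OCc1ccccc1)c1ccc(NS(C)(=O)=O)c(F)c1` gives 0.9 nM in an assay on CHO cells for antagonist activity at transient receptor potential cation channel subfamily V member 1 (Homo sapiens), read by FLIPR; on this read-out lower numbers stand for stronger inhibition and higher numbers for weaker inhibition. Compound 2 `CC(C(=O)NCc1ccc(C(F)(F)F)cc1OCc1ccc(F)cc1)c1ccc(NS(C)(=O)=O)c(F)c1` carries one change, (fluoro in place of hydrogen on an aromatic carbon), and in this assay compound 2 gives 0.5 nM, a step of a 1.8-fold lower number from compound 1 to compound 2 (0.26 log units; within the scatter). Compound 3 `CC(C(=O)NCc1ccc(C(F)(F)F)cc1-c1cccc(Cl)c1)c1ccc(NS(C)(=O)=O)c(F)c1` rests on a different core; the difference between the cores is 3-chlorophenyl in place of benzyloxy on an aromatic carbon, and in this assay compound 3 gives 1 nM, with a 1.1-fold higher number from compound 1 to compound 3 (0.05 log units; within the scatter). Compound 4 `CC(C(=O)NCc1ccc(C(F)(F)F)cc1-c1ccc(F)c(Cl)c1)c1ccc(NS(C)(=O)=O)c(F)c1` is not yet measured and differs from compound 3 by fluoro in place of hydrogen on an aromatic carbon. Within the data shown here, this is the same kind of change as the one between compound 1 and compound 2, though the place is not identical: here the entering fluoro sits ortho to a chloro group as well as para to a large group. Because a 1.8-fold lower number from compound 1 to compound 2 (0.26 log units; within the scatter) stayed within the scatter, a similarly small step is expected for compound 4, a 1.4-fold lower number from compound 3 to compound 4 (0.15 log units; within the scatter). Compound 4 is estimated at 0.7 nM, between 0.3 nM and 1.6 nM.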

Compound 4, inhibition constant: 0.6 nM
For compound 4 the middle estimate is 1.2-fold (0.07 log units) above the measured one; low and high end bracket the measured number.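

In this assay adding the fluoro to the core of compound 3 gives only a small step (a 1.7-fold lower number from compound 3 to compound 4 (0.22 log units; within the scatter)), and no real gain can be claimed from it alone. Exchanging the whole side group also stays small (a 1.2-fold higher number from compound 2 to compound 4 (0.08 log units; within the scatter)) and (a 1.5-fold lower number from compound 1 to compound 4 (0.18 log units; within the scatter)), and two cores are too few for a rule across the series. Still, on these two cores the fluoro step carries over with no detectable difference: the same change on two cores in this assay, a 1.8-fold lower number (0.26 log units; within the scatter) from compound 1 to compound 2 and a 1.7-fold lower number (0.22 log units; within the scatter) from compound 3 to compound 4, 1.1-fold (0.03 log units) apart, within the scatter of two such steps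

From the compounds shown here alone, it remains open whether the same small step would appear on a third core. Also open, going by these compounds, is what a methoxy group or a nitrile would do in place of the fluoro on this aromatic carbon.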